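Sulfonyl substituent series: from methyl to amino

This account rests on a few compounds, and the source may have more. Where it says the series, first, only, none or still open, it means among the compounds named here.

Measured compounds:
compound 1 `CCN1CCCC1CNC(=O)c1cc(NS(=O)(=O)N(C)C)c(C)cc1OC` — 13.3 mg/kg
compound 2 `CCN1CCCC1CNC(=O)c1cc(NS(C)(=O)=O)c(C)cc1OC` — 35.6 mg/kg

For the measured compounds named here, compound 2 stands at the higher of the two numbers so far. Going by the values given here, in a functional assay on the whole organism for inhibition, with Mus musculus as the target (a higher number here means that more compound is needed for the effect, a lower number that less compound is needed), compound 2 gives 35.6 mg/kg, while compound 1 gives 13.3 mg/kg; the one computed step, a 2.7-fold higher number from compound 1 to compound 2 (0.43 log units; beyond the scatter), marks methyl in place of dimethylamino on the sulfonyl sulfur as a modest move toward a higher number.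

Compound 3 `CCN1CCCC1CNC(=O)c1cc(NS(N)(=O)=O)c(C)cc1OC` has not yet been tested. It differs from compound 2 in one place: amino in place of methyl on a sulfonyl sulfur. Among the compounds with values here, the change returns a nitrogen to the sulfonyl sulfur, so the step from compound 1 to compound 2 is the only measured step that bears on it, though it is not a mirror image of that step, amino being a different group from dimethylamino. Within the data shown here, on this reading the expected step is a 1.6-fold lower number from compound 2 to compound 3 (0.21 log units; within the scatter), a modest move back toward a lower number, with wide uncertainty since no measured compound carries a sulfamoyl group. The estimate for compound 3 in this assay is 22 mg/kg, within a range from 8 mg/kg to 60 mg/kg.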

Compound 3, dose for half-maximal effect: > 50 mg/kg
Compound 3: a limit, no number; the forecaster's own chance of this, stated with the estimate: 5%; middle value at least 2.2-fold (0.35 log units) away from the limit.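

In this assay compound 3 carries a limit and not a number: the limit of > 50 mg/kg in this assay, at which 1 of the 3 values shown sits.

Read as a step, amino in place of methyl on the sulfonyl sulfur gives an at least 1.4-fold higher number from compound 2 to compound 3 (0.14 log units; that floor lies within the scatter), so the limit does not set the two compounds apart and no order between them can be stated. Amino in place of dimethylamino gives an at least 3.7-fold higher number from compound 1 to compound 3 (0.57 log units; beyond the scatter), which shows that among these three compounds the lower number goes with dimethylamino and not with just any nitrogen on the sulfonyl sulfur, so the methyl groups on that nitrogen matter to the result.

On these data alone, how far the number for compound 3 lies past its limit remains open, and with it the true size of both steps. Also open, as far as these compounds go, is whether methylamino, which stands between amino and dimethylamino, or a larger group on the same sulfur such as diethylamino or pyrrolidinyl would keep the number of compound 1, lower it further or raise it.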